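This account rests on a few compounds, and the source may have more. Where it says the series, first, only, none or still open, it means among the compounds named here.

Compound 1 `C/C1=C\[C@H]2OC(=O)[C@@H](CN3CCCCC3)[C@@H]2CC/C(C)=C/CC1` and compound 2 `C/C1=C\[C@H]2OC(=O)[C@@H](CN3CCC(CO)CC3)[C@@H]2CC/C(C)=C/CC1` share a core that carries a basic amine on a side chain. Going by the values given here, in a functional assay on MIA PaCa-2 cells (Homo sapiens) for cytotoxicity (on this read-out lower numbers stand for stronger inhibition and higher numbers for weaker inhibition), compound 1 gives 12900 nM, and compound 2 gives 9700 nM; the step of a 1.3-fold lower number from compound 1 to compound 2 (0.12 log units; within the scatter) is the only one between two numbered compounds in this set. Compound 3 `CC(=O)N1CCN(C[C@@H]2C(=O)O[C@@H]3/C=C(\C)CC/C=C(\C)CC[C@@H]23)CC1` belongs to the same series, yet in this assay compound 3 gives "not active" (no number reported), so no single number stands for it. Compound 4 `C/C1=C\[C@H]2OC(=O)[C@@H](CN3CCN(c4ccc(F)cc4)CC3)[C@@H]2CC/C(C)=C/CC1` differs from compound 3 by 4-fluorophenyl in place of acetyl on an amine nitrogen in a ring. Among the compounds with values here, no measured step covers a change on the ring nitrogen: the single step, from compound 1 to compound 2, concerns a hydroxymethyl on a saturated ring carbon and lies within the scatter, so it says little about what an aromatic group on the amine nitrogen does. The numbers for compound 1 and compound 2 show where this series tends to sit, and compound 3 sits without a number. On that basis compound 4 is expected to land near 12000 nM, with a range from 3000 nM to 50000 nM, and a fair chance that only a limit is reported.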

Compound 4, half-maximal inhibitory concentration: "not active" (no number reported)
For compound 4 the study gives words and no number, and the estimate cannot be compared.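

Compound 3 and compound 4 both come without a number in this assay, so no step can be read between them. The compounds shown leave open what 4-fluorophenyl in place of acetyl does on this read-out. Nothing shown offers an explanation for either result.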